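Removing One Chloro Group: From Compound 3 to Compound 4

The compounds below may be only part of what the source reports. "The series", "measured", "known", "first", "only" and "open" are said of these compounds alone.

Measured so far in an in vitro functional assay on HEK293-A cells for positive allosteric modulation of metabotropic glutamate receptor 5 (Homo sapiens), read by FLIPR and calcium flux; on this read-out higher numbers stand for an effect only at larger amounts of compound and lower numbers for an effect already at smaller amounts:
- compound 1 `O=C1CC(c2nc(-c3ccc(F)cc3)no2)CN1c1ccc(Cl)cc1` gives 1700 nM
- compound 2 `Cc1cccc(-c2noc(C3CC(=O)N(c4ccc(Cl)cc4)C3)n2)n1` reaches only the assay limit, > 10000 nM
- compound 3 `O=C1CC(c2nc(-c3cccc(F)c3)no2)CN1c1ccc(Cl)c(Cl)c1` gives 3200 nM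

Compound 3 holds the higher of the two plain numbers, yet its gap to compound 1 lies within the scatter, so the two cannot be ranked. The value of compound 2 is a limit, not a number (the limit of > 10000 nM in this assay, at which 1 of the 3 values shown sits).

Compound 4 `O=C1CC(c2nc(-c3cccc(F)c3)no2)CN1c1ccc(Cl)cc1` differs from compound 3 in a single place: hydrogen in place of chloro on an aromatic carbon. Going by the values given here, no measured step covers this kind of change; the only measured step, an at least 5.8-fold higher number from compound 1 to compound 2 (0.76 log units; beyond the scatter), concerns a different part of the molecule and offers no guide here. With nothing pointing either way, the estimate for compound 4 is a change no larger than the scatter, a 1.3-fold lower number from compound 3 to compound 4 (0.11 log units; within the scatter). Compound 4 is therefore expected near 2500 nM, between 1000 nM and 7000 nM.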

Compound 4, half-maximal effective concentration: 630 nM
Compound 4: the middle estimate sits 4.0-fold (0.60 log units) above what was measured, and the stated range ends above it.
By their numbers in this assay, from the lowest: compound 4; then compounds 1 and 3 (each within the scatter of the next). At a limit, above all of these: compound 2.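

Going by these compounds alone, replacing the chloro group with hydrogen, which turns 3,4-dichlorophenyl into 4-chlorophenyl, gives the first step at this position, a 5.1-fold lower number from compound 3 to compound 4 (0.71 log units; beyond the scatter), so this aromatic carbon does affect the read-out. On the other aromatic ring, 3-fluorophenyl in place of 4-fluorophenyl gives a 2.7-fold lower number from compound 1 to compound 4 (0.43 log units; beyond the scatter), while the change from 6-methylpyridin-2-yl gives an at least 15-fold lower number from compound 2 to compound 4 (1.20 log units; beyond the scatter). The value of compound 2 is a limit, not a number: the limit of > 10000 nM in this assay, at which 1 of the 4 values shown sits.

On these data alone, it remains open whether a methyl or methoxy group on this aromatic carbon would raise or lower the number. As far as these compounds go, it is also open whether removing the chloro group would give a similar step alongside 4-fluorophenyl.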